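The source may hold more compounds than are shown below. What is called first, only, known or untested is meant among the compounds shown, and "the series" means these compounds.

Compound 1 `O=C(Nc1ccccc1)C1CCN(C/C=C/c2ccccc2)CC1` is tested in a functional assay on MGC-803 cells (Homo sapiens) for inhibition, read by MTT assay, with a stated time of 72 h (on this read-out higher numbers stand for weaker inhibition and lower numbers for stronger inhibition), where compound 1 gives 57900 nM. Among the three measured compounds this is the second highest number. Compound 3 `COc1ccc(NC(=O)C2CCN(C/C=C/c3ccccc3)CC2)cc1` sits right beside it, giving 58200 nM in this assay, and the step of a 1.0-fold higher number from compound 1 to compound 3 (0.00 log units; within the scatter) shows that adding a methoxy group changes nothing that can be trusted. Compound 2 `CCCCc1ccc(NC(=O)C2CCN(C/C=C/c3ccccc3)CC2)cc1` is the outlier, giving 2570 nM in this assay; the step of a 23-fold lower number from compound 1 to compound 2 (1.35 log units; beyond the scatter) is a large gain in inhibition from a butyl group, and the step of a 23-fold higher number from compound 2 to compound 3 (1.35 log units; beyond the scatter) shows the same gap from the other side.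

Compound 4 `CN1CCN(c2ccc(NC(=O)C3CCN(C/C=C/c4ccccc4)CC3)cc2)CC1` carries a different substituent at the same position: 4-methylpiperazin-1-yl in place of hydrogen on an aromatic carbon. Neither measured step tested a group of this kind, so the two available steps only set the scene: one small substituent gave a large gain, another gave none. The new group is larger and ring-shaped, unlike both. A step somewhere between those two outcomes seems the fairest expectation, with wide uncertainty. Compound 4 is therefore estimated at 20000 nM in this assay, within 4000 nM to 70000 nM, which would mean an expected step of a 2.9-fold lower number from compound 1 to compound 4 (0.46 log units; beyond the scatter).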

Compound 4, half-maximal inhibitory concentration: 14000 nM
Compound 4: the middle estimate sits 1.4-fold (0.15 log units) above what was measured, within the range that was stated.
By their numbers in this assay, from the lowest: compound 2; then compound 4; then compounds 1 and 3 (each within the scatter of the next).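

In this assay the position para to a large group gives a real gain with a ring-shaped substituent as well: 4-methylpiperazin-1-yl improves on plain hydrogen, with a 4.1-fold lower number from compound 1 to compound 4 (0.62 log units; beyond the scatter), and by much the same amount on methoxy, with a 4.2-fold lower number from compound 3 to compound 4 (0.62 log units; beyond the scatter). Butyl is therefore not the only group among those shown that lowers the number here, although it remains ahead of the new group, with a 5.4-fold higher number from compound 2 to compound 4 (0.74 log units; beyond the scatter), while methoxy goes against any idea that every added group helps. The data shown offer no measurement that explains why these substituents differ, so this order is only an observation.

The compounds shown leave open whether the gain with 4-methylpiperazin-1-yl depends on the whole ring or on its methyl group, which a piperazine without that methyl or a morpholine ring at the same place would help to separate. On these data alone, it also remains unknown how far the butyl result extends, for example to a shorter ethyl chain, a longer hexyl chain or a carboxylic acid at this position.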